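This account rests on a few compounds, and the source may have more. Where it says the series, first, only, none or still open, it means among the compounds named here.

In a functional assay on CCRF-CEM cells (Homo sapiens) for inhibition, read by sulforhodamine B assay, with a stated time of 48 h, tested at 0.1 uM (on this read-out higher numbers stand for a weaker effect at the one concentration tested and lower numbers for a stronger effect), compound 1 `O=C(Nc1cccc(-n2cc(-c3ccncc3)c(-c3cc(O)cc(Cl)c3)n2)c1)Nc1ccc(Cl)c(C(F)(F)F)c1` gives 95%, and compound 2 `O=C(Nc1cccc(-n2cc(-c3ccncc3)c(-c3cc(O)cc(Cl)c3)n2)c1)Nc1ccc(Cl)c(Cl)c1` gives 95%. These two differ only by chloro in place of trifluoromethyl on an aromatic carbon, and no change at the digits printed from compound 1 to compound 2 (within the scatter). Compound 3 `COc1cc(Cl)cc(-c2nn(-c3cccc(NC(=O)Nc4cc(C(F)(F)F)cc(C(F)(F)F)c4)c3)cc2-c2ccncc2)c1` gives 84% in this assay, the lowest of the three numbers; it stands below compound 1 and below compound 2 by a gap beyond the scatter, so among the measured compounds it shows the strongest effect.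

Compound 4 `COc1cc(Cl)cc(-c2nn(-c3cccc(NC(=O)Nc4cccc(C(F)(F)F)c4)c3)cc2-c2ccncc2)c1` has not yet been measured in this assay. It differs from compound 3 by hydrogen in place of trifluoromethyl on an aromatic carbon. The trifluoromethyl that leaves sits on a six-membered aromatic ring of carbon only, meta to a large group and meta to a trifluoromethyl group, and the ring keeps its other trifluoromethyl.

Among the measured compounds shown here, no measured step removes a trifluoromethyl outright. The only step shown, no change at the digits printed from compound 1 to compound 2 (within the scatter), exchanges one small group for another on an aromatic carbon and left the number unchanged, which gives only a weak hint that a small change at such a position moves the number little. For compound 4 the step of a number 4 percentage points higher from compound 3 to compound 4 (within the scatter) is therefore expected to stay within the scatter, leaning if anything toward a weaker effect. Compound 4 is estimated at 88%, with a range from 78% to 98%.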

Compound 4, a percentage reported as activity, at one concentration (the size of the read-out at that concentration, not a potency): 97%
Beside the measured number, compound 4's estimate is 9 percentage points below it; the range from low to high includes it.
By their numbers in this assay, from the lowest: compound 3; then compounds 1, 2 and 4 (each within the scatter of the next).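

In this assay, taking one trifluoromethyl off the ring that carries two gives a number 13 percentage points higher from compound 3 to compound 4 (beyond the scatter), a modest step but one beyond the usual scatter. This is the first step shown that removes a group outright, and it shows that the number responds to what sits on this aromatic carbon, meta to a large group and meta to a trifluoromethyl group: with hydrogen there, the effect at the one concentration tested is weaker. The earlier step, no change at the digits printed from compound 1 to compound 2 (within the scatter), exchanged trifluoromethyl for chloro in a different setting and left the number unchanged, but nothing shown offers a reason for the difference between the two steps.

The compounds shown leave open whether chloro at this same place would hold the number as trifluoromethyl does, and how an amine or a carboxylic acid there would read. They also leave open whether removing this trifluoromethyl has the same result when the methoxy on the other ring is replaced by the hydroxyl of compounds 1 and 2.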